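Furan-bearing series: propyl in place of trifluoromethyl

This account rests on a few compounds, and the source may have more. Where it says the series, first, only, none or still open, it means among the compounds named here.

Measured compounds:
compound 1 `CC1=C(C(N)=O)C(c2ccco2)NC(=O)N1`, 2%
compound 2 `CC1=C(C(=O)OC(C)(C)C)C(c2ccco2)NC(=O)N1`, 7%
compound 3 `CCOC(=O)C1=C(C(F)(F)F)NC(=O)NC1c1ccco1`, 2%

In an assay on HeLa cells for displacement of a labelled ligand from adenosine receptor A3 (Homo sapiens), with a stated time of 180 min, tested at 10 uM (on this read-out lower numbers stand for less inhibition and higher numbers for more inhibition at the one concentration tested (going by the name of the read-out)), compound 3 stands level with compound 1 at the digits shown, the two together the lowest of the three numbers; compound 2 sits a little higher, within the scatter. Among the measured compounds shown here, the one single-point step measured so far, a number 5 percentage points higher from compound 1 to compound 2 (within the scatter), concerns a different place on the shared core and stays within the scatter.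

Compound 4 `CCCC1=C(C(=O)OCC)C(c2ccco2)NC(=O)N1` differs from compound 3 by propyl in place of trifluoromethyl on a double-bonded ring carbon. For the measured compounds named here, no measured step touches this ring position, so no direction can be read from the data. Compound 4 is expected to give 3% (range 0% to 12%), a step of a number 1 percentage points higher from compound 3 to compound 4 (within the scatter) that is estimated to stay within the scatter.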

Compound 4, a percentage reported as inhibition, at one concentration (the size of the read-out at that concentration, not a potency): 19%
Compound 4: middle estimate off by 16 percentage points, on the low side; the measured number lies above the stated range.
By their numbers in this assay, from the lowest: compounds 1, 3 and 2 (each within the scatter of the next); then compound 4.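

Among the compounds shown here, this position, on a double-bonded ring carbon next to the ring nitrogen, gives the first single change to pass the scatter in this assay: propyl in place of trifluoromethyl gives a number 17 percentage points higher from compound 3 to compound 4 (beyond the scatter). For the compounds shown here, the only earlier step, at a carbonyl carbon, stayed within the scatter. No measurement available bears on why the number rises at this position.

Open, as far as these compounds go, is whether the rise belongs to propyl itself or to the absence of trifluoromethyl. A longer chain such as pentyl, or an amine on this carbon, would help separate the two.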